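Hydroxy to fluoro: next step in the series

The source may hold more compounds than are shown below. What is called first, only, known or untested is meant among the compounds shown, and "the series" means these compounds.

In a functional assay on MGC-803 cells (Homo sapiens) for cytotoxicity, read by MTT assay, with a stated time of 72 h (on this read-out lower numbers stand for stronger inhibition and higher numbers for weaker inhibition), compound 1 (`CCC(C)=C1C(=O)N(c2ccc(Cl)cc2)N(c2ccc(Cl)cc2)C1=O`) gives 66500 nM, compound 2 (`O=C1C(=Cc2ccc(O)cc2)C(=O)N(c2ccc(Cl)cc2)N1c1ccc(Cl)cc1`) gives 19500 nM and compound 3 (`CN(C)c1ccc(C=C2C(=O)N(c3ccc(Cl)cc3)N(c3ccc(Cl)cc3)C2=O)cc1`) gives 80200 nM. Compound 2 holds the lowest of these three numbers, and its gaps to both others lie beyond the scatter. Next comes compound 4 (`O=C1C(=Cc2ccc(F)cc2)C(=O)N(c2ccc(Cl)cc2)N1c1ccc(Cl)cc1`), with fluoro in place of hydroxy on an aromatic carbon, para to a large group: fluoro in place of hydroxy on an aromatic carbon. Going by the values given here, one measured step bears on this place: a 4.1-fold higher number from compound 2 to compound 3 (0.61 log units; beyond the scatter), a modest rise with dimethylamino as the incoming group. This is a single step with a different group, so it offers only a weak lean. Among the compounds with values here, no measured compound yet carries fluoro here. A small rise is expected in this assay, near the edge of the scatter, and no real change remains possible. The expected step is a 1.9-fold higher number from compound 2 to compound 4 (0.29 log units; within the scatter). The estimate for compound 4 is 38000 nM, with an expected range from 13000 nM to 95000 nM.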

Compound 4, half-maximal inhibitory concentration: 26000 nM
For compound 4 the middle estimate is 1.5-fold (0.16 log units) above the measured one; the range from low to high includes it.
By their numbers in this assay, from the lowest: compounds 2 and 4 (each within the scatter of the next); then compounds 1 and 3 (each within the scatter of the next).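

In this assay, going by these compounds alone, the change from 4-hydroxyphenyl to 4-fluorophenyl reads as a 1.3-fold higher number from compound 2 to compound 4 (0.12 log units; within the scatter) and shows no real change at this place, so hydroxy is not the only group here that holds the level of compound 2. Fluoro in place of dimethylamino gives a 3.1-fold lower number from compound 3 to compound 4 (0.49 log units; beyond the scatter) and puts compound 4 level with compound 2, so the rise seen with compound 3 does not extend to every replacement of hydroxy. Nothing measured here gives a reason for either step.

The compounds shown leave open how methoxy, chloro, a primary amine or a carboxylic acid would read at this place, and whether a plain phenyl with no group here stays at the same level. Also open, on these data alone, is whether hydroxy and fluoro still read alike when the rest of the shared core is changed.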